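The Opposite Hand at the Chain Carbon

A few compounds are considered here, and "the series" means these few. Any claim that something is new, unique, unknown or untested is made for them only; others in the source may bear on it.

Among the compounds with values here, compound 2 `CC(=O)Nc1ccc([C@H](C)NCC2CCN(CCCc3c[nH]c4ccc(-n5cnnc5)cc34)CC2)cc1` stands lowest of the two numbers so far in an assay on CHO cells for displacement of a labelled ligand from 5-hydroxytryptamine receptor 1D (Homo sapiens) (a lower number here means a stronger inhibitor, a higher number a weaker inhibitor), where compound 2 gives 0.6 nM. Its nearest neighbour is compound 1 `c1ccc(CNCC2CCN(CCCc3c[nH]c4ccc(-n5cnnc5)cc34)CC2)cc1`, and in this assay compound 1 gives 1.6 nM; the step of a 2.7-fold lower number from compound 1 to compound 2 (0.43 log units; beyond the scatter) came from placing 1-(4-acetamidophenyl)ethyl in place of benzyl on the amine nitrogen, a move beyond the scatter.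

Within the data shown here, compound 3 `CC(=O)Nc1ccc([C@@H](C)NCC2CCN(CCCc3c[nH]c4ccc(-n5cnnc5)cc34)CC2)cc1` is the next compound. the two compounds have the same atoms and bonds and differ only in configuration as drawn: 1 of 1 stereo elements differ; a stereocentre at a saturated chain carbon is drawn S in compound 2 and R in compound 3 No measured step bears directly on this change: the only step at hand, a 2.7-fold lower number from compound 1 to compound 2 (0.43 log units; beyond the scatter), exchanges one group for another rather than inverting a stereocentre, and compound 1 carries no such centre at all. The size of the step in this assay therefore cannot be read from the numbers. What the data do show is that compound 1, which lacks the methyl at that carbon, sits close to compound 2, so inverting the centre is expected to move the number upward by a modest to larger amount rather than downward. The expected step from compound 2 to compound 3 is a 4.2-fold higher number from compound 2 to compound 3 (0.62 log units; beyond the scatter). Compound 3 is thus estimated to give about 2.5 nM in this assay, within a range from 0.6 nM to 12 nM.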

Compound 3, half-maximal inhibitory concentration: 1.5 nM
The estimate for compound 3 lay 1.7-fold (0.22 log units) above the measured number; low and high end bracket the measured number.
By their numbers in this assay, from the lowest: compound 2; then compounds 3 and 1 (each within the scatter of the next).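

Inverting the stereocentre at the saturated chain carbon gives a 2.5-fold higher number from compound 2 to compound 3 (0.40 log units; beyond the scatter), so the number in this assay responds to the hand of this centre, though only modestly. The gap can be assigned to that centre alone because of one structural fact: the fact that compounds 2 and 3 differ only in the configuration as drawn. The inversion also qualifies the earlier gain from 1-(4-acetamidophenyl)ethyl in place of benzyl: with the centre drawn R, the same exchange gives a 1.1-fold lower number from compound 1 to compound 3 (0.03 log units; within the scatter), so of the two hands only the S form stands apart from the benzyl compound.

Both hands carry the acetamido group, so the compounds shown leave open whether the gap between the hands survives with a plain 1-phenylethyl group or with a methanesulfonamide in place of the acetamide. They also leave open how the number would respond to an ethyl group in place of the methyl at the chain carbon, and whether the S form would still stand apart from the benzyl compound with that larger chain at the centre.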